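A few compounds are considered here, and "the series" means these few. Any claim that something is new, unique, unknown or untested is made for them only; others in the source may bear on it.

Of the compounds shown here, three sharing one core have been tested in an ADME assay on HEL cells (Homo sapiens) for cytotoxicity, with a stated time of 3 days; a higher number here means that more compound is tolerated, a lower number that less compound is tolerated. Compound 1 `CCC1(Cc2ccccc2)OS(=O)(=O)C=C1OCCCCc1ccccc1` carries a 3-phenylpropyl on the saturated chain carbon bound to the oxygen on the unsaturated carbon, and in this assay compound 1 gives 99000 nM. Compound 3 `CCC1(Cc2ccccc2)OS(=O)(=O)C=C1OCc1ccccc1Cl` carries a 2-chlorophenyl at that place instead, and in this assay compound 3 gives 38000 nM; the change from compound 1 to compound 3 was a 2.6-fold lower number from compound 1 to compound 3 (0.42 log units; beyond the scatter). Compound 2 `CCC1(Cc2ccccc2)OS(=O)(=O)C=C1OCc1ccc(F)cc1` carries a 4-fluorophenyl at that place. For compound 2 in this assay only a limit is known, > 50000 nM, which is the limit of > 50000 nM in this assay, at which 1 of the 3 values shown sits. So compound 2 stands at a limit rather than at a number, not at a point on the scale.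

Compound 4 `CCC1(Cc2ccccc2)OS(=O)(=O)C=C1OCc1ccc(C(F)(F)F)cc1` is not yet measured. It differs from compound 2 in one place: trifluoromethyl in place of fluoro on an aromatic carbon. For the measured compounds named here, two measured steps bear on this change. The readable one is an at least 1.3-fold lower number from compound 2 to compound 3 (0.11 log units; that floor lies within the scatter). The other, a step that the limit leaves unreadable from compound 1 to compound 2, gives no size. Going by the values given here, with every measured compound giving a high number and the one readable step from compound 2 having its floor within the scatter, no step beyond the scatter is expected. The expected step is a number no higher from compound 2 to compound 4 (the limit leaves the size open). Compound 4 is estimated at 50000 nM, expected to fall between 20000 nM and 120000 nM.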

Compound 4, half-maximal cytotoxic concentration: 99000 nM
For compound 4 the middle estimate is 2.0-fold (0.30 log units) below the measured one, within the range that was stated.
By their numbers in this assay, from the lowest: compound 3; then compounds 1 and 4 (each within the scatter of the next).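

No size can be read for the change from compound 2 to compound 4, because compound 2 has only a limit and not a number: the limit of > 50000 nM in this assay, at which 1 of the 4 values shown sits.

The compounds shown leave open whether trifluoromethyl in place of fluoro on the aromatic carbon alters how much compound the cells tolerate, and by how much.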